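This account rests on a few compounds, and the source may have more. Where it says the series, first, only, none or still open, it means among the compounds named here.

Measured so far in a functional assay on PC-3 cells (Homo sapiens) for antiproliferative activity, read by sulforhodamine B assay, with a stated time of 48 h; a higher number here means a weaker inhibitor, a lower number a stronger inhibitor
compound 1 `O=C(CCCCCCN1C(=O)/C(=N\O)c2cc(F)ccc21)NO` gives 2730 nM
compound 2 `CO/N=C1/C(=O)N(CCCCCCC(=O)NO)c2ccc(F)cc21` gives 1150 nM
compound 3 `CO/N=C1/C(=O)N(CCCCCCC(=O)NO)c2ccc(Cl)cc21` gives 2330 nM

Compound 3 sits at the upper end of these numbers together with compound 1, the two lying within the scatter of each other, while compound 2 stands apart at the low end. Next comes compound 4 `CO/N=C1/C(=O)N(CCCCCCC(=O)NO)c2ccc(C)cc21` with the shared core and chain of compound 3 unchanged. The change, methyl in place of chloro on an aromatic carbon, is methyl in place of chloro on an aromatic carbon and nothing else differs. Among the measured compounds shown here, one measured step bears on this: a 2.0-fold higher number from compound 2 to compound 3 (0.31 log units; beyond the scatter) with chloro in place of fluoro on an aromatic carbon, a modest move. For the measured compounds named here, no measured compound carries methyl on that carbon, so the data give no direction for this change. A large shift in this assay is not expected, and no step beyond the scatter is expected either. The estimated change is a 1.2-fold lower number from compound 3 to compound 4 (0.07 log units; within the scatter) and remains within the scatter. Compound 4 is estimated at 2000 nM with an expected range from 1000 nM to 4000 nM in this assay for now.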

Compound 4, half-maximal inhibitory concentration: 350 nM
Estimate against measurement, compound 4: 5.7-fold (0.76 log units) above; measured number outside the range, below it.
By their numbers in this assay, from the lowest: compound 4; then compound 2; then compounds 3 and 1 (each within the scatter of the next).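

In this assay, methyl on this aromatic carbon gives a 6.7-fold lower number from compound 3 to compound 4 (0.82 log units; beyond the scatter) and a 3.3-fold lower number from compound 2 to compound 4 (0.52 log units; beyond the scatter), both beyond the scatter. The position therefore responds more strongly than the exchange of fluoro for chloro alone suggested, and among the three compounds that differ only here, the numbers rise in the order methyl, fluoro, chloro. No measurement available here accounts for this order or for the size of these steps.

Going by these compounds, three groups on one carbon set no trend, so it remains open whether ethyl, methoxy or trifluoromethyl at this place would give a number near that of compound 4 or nearer those of compound 2 and compound 3. Also open, on these data alone, is whether methyl would give a similar step on the oxime of compound 1, which carries fluoro here.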